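The source may report more compounds than this note shows. Statements on the series, on what has been measured and on what is new or still open speak of the compounds shown alone.

Measured compounds:
compound 1 `N#Cc1c(Nc2ccc(N)cc2)sc2ccccc12`, 1% in a functional assay on HUVEC cells (Homo sapiens), read by fluorescence and microscopy, with a stated time of 6 h, tested at 10 uM; on this read-out higher numbers stand for a weaker effect at the one concentration tested and lower numbers for a stronger effect
compound 2 `COc1cccc(Nc2sc3ccccc3c2C#N)c1`, 81% in this assay

Within the data shown here, compound 1 stands at the lowest of the two numbers, the stronger effect; compound 2 lies a long way higher, beyond the scatter, though no single-point step links the two. Compound 3 `N#Cc1c(Nc2ccc(O)cc2)sc2ccccc12` is the unmeasured neighbour of compound 1. The change from compound 1 to compound 3 is hydroxy in place of amino on an aromatic carbon. Among the measured compounds shown here, with no measured step of this kind to lean on, the expectation is a small rise in this assay, a weakening that may or may not exceed the scatter: the step from compound 1 to compound 3 is estimated at a number 19 percentage points higher from compound 1 to compound 3 (beyond the scatter). Compound 3 is therefore expected to give about 20%, between 2% and 60%.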

Compound 3, a percentage reported as activity, at one concentration (the size of the read-out at that concentration, not a potency): 25%
The estimate for compound 3 lay 5 percentage points below the measured number; measured number inside the range.
By their numbers in this assay, from the lowest: compound 1; then compound 3; then compound 2.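

In this assay, among these compounds, putting hydroxy in place of amino on an aromatic carbon, para to a large group, gives a number 24 percentage points higher from compound 1 to compound 3 (beyond the scatter) and is the first single-place step measured at this position. It shows that this position responds to the exchange, yet compound 3 stays at 25% and so keeps much of the effect. No measurement at hand accounts for this step. The compounds shown leave open how a dimethylamino group or a carboxylic acid on the same carbon would read in this assay and whether either would match amino there.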